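Estimating a chlorophenyl analogue from three measured neighbours

The compounds below may be only part of what the source reports. "The series", "measured", "known", "first", "only" and "open" are said of these compounds alone.

Compound 1 `Cc1ccc(NC(=O)COc2ccc3cc(/C=C4/SC(=O)NC4=O)ccc3c2)cc1` in a functional assay on CCRF-CEM cells (Homo sapiens) for cytotoxicity, with a stated time of 20 h (on this read-out higher numbers stand for lower toxicity in this test and lower numbers for higher toxicity in this test), gives 2800 nM
Compound 2 `COc1cccc(NC(=O)COc2ccc3cc(/C=C4/SC(=O)NC4=O)ccc3c2)c1` gives 10700 nM
Compound 3 `O=C(COc1ccc2cc(/C=C3/SC(=O)NC3=O)ccc2c1)Nc1c(F)cc(F)cc1Br` gives 9600 nM

Compound 3 cannot be told apart from its nearest neighbour, the step being a 1.1-fold lower number from compound 2 to compound 3 (0.05 log units; within the scatter) here. Its furthest neighbour has a clearly lower number, the step being a 3.4-fold higher number from compound 1 to compound 3 (0.54 log units; beyond the scatter) in this case.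

Compound 4 `O=C(COc1ccc2cc(/C=C3/SC(=O)NC3=O)ccc2c1)Nc1cccc(Cl)c1` has not yet been measured. The change is 3-chlorophenyl in place of 2-bromo-4,6-difluorophenyl on an amide-type nitrogen.

Within the data shown here, the only guides are earlier swaps on this same nitrogen. These have been modest at most, as in a 3.8-fold higher number from compound 1 to compound 2 (0.58 log units; beyond the scatter), so no large step is expected in this assay. With compound 1 at 2800 nM and compound 2 at 10700 nM marking the span so far, a position inside that span is expected. The estimated step is a 1.6-fold lower number from compound 3 to compound 4 (0.20 log units; within the scatter), so a change beyond the scatter is not expected. For compound 4 the estimated value is 6000 nM, with an expected range from 2500 nM to 13000 nM.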

Compound 4, half-maximal cytotoxic concentration: 10600 nM
For compound 4 the middle estimate is 1.8-fold (0.25 log units) below the measured one; the measured number falls inside the stated range.
By their numbers in this assay, from the lowest: compound 1; then compounds 3, 4 and 2 (each within the scatter of the next).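

In this assay the 3-chlorophenyl group on the amide-type nitrogen cannot be told apart from the 2-bromo-4,6-difluorophenyl group (a 1.1-fold higher number from compound 3 to compound 4 (0.04 log units; within the scatter)) or from the 3-methoxyphenyl group (a 1.0-fold lower number from compound 2 to compound 4 (0.00 log units; within the scatter)). Compounds 2, 3 and 4 therefore form one group despite their different ring substituents, while compound 1, with its 4-methylphenyl group, stands apart from compound 4 (a 3.8-fold higher number from compound 1 to compound 4 (0.58 log units; beyond the scatter)), as it does from the other two. No measurement shown here explains this grouping or the separate position of compound 1.

The compounds shown leave open whether compound 1 is set apart by its methyl group specifically or by some other feature of its 4-methylphenyl group. They also leave open how a phenyl ring carrying an amine or a carboxylic acid would behave on this nitrogen.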